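Series notes: the group on the chain carbon at the ring nitrogen

The compounds below may be only part of what the source reports. "The series", "measured", "known", "first", "only" and "open" are said of these compounds alone.

Compound 3 `CCCSc1nc(Cl)c2c(n1)N(Cc1ccccc1)C(C(=O)N1CCN(C)CC1)N2` sits at the edge of what a functional assay on MGC-803 cells (Homo sapiens) for antiproliferative activity, read by MTT assay, with a stated time of 72 h (a lower number here means a stronger inhibitor, a higher number a weaker inhibitor), can report. In this assay compound 3 gives only a limit, > 64000 nM. Compound 2 `CCCSc1nc(Cl)c2c(n1)N(CC1CCCCC1)C(C(=O)N1CCN(C)CC1)N2` likewise gives only a limit in this assay, > 64000 nM. Within the data shown here, compound 1 `CCCSc1nc(Cl)c2c(n1)N(Cc1cccs1)C(C(=O)N1CCN(C)CC1)N2` is the one member with a number, 62300 nM. The measured steps therefore read as floors: an at least 1.0-fold higher number from compound 1 to compound 2 (0.01 log units; that floor lies within the scatter) and an at least 1.0-fold higher number from compound 1 to compound 3 (0.01 log units; that floor lies within the scatter), while a step that the two limits leave unreadable from compound 2 to compound 3. The three compounds share one core and differ only in the group on the saturated chain carbon bound to the ring nitrogen, and whether that group is thiophen-2-yl, cyclohexyl or phenyl, the read-out stays at or near the same place, as the limit of > 64000 nM in this assay, at which 2 of the 3 values shown sit, shows.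

Compound 4 `CCCSc1nc(Cl)c2c(n1)N(CCNC(=O)OC(C)(C)C)C(C(=O)N1CCN(C)CC1)N2` carries the change (((tert-butoxycarbonyl)amino)methyl in place of phenyl on a saturated chain carbon bound to a nitrogen on an aromatic ring in a ring). No measured step covers this change; the three shown steps all concern swaps among ring groups at this position, and none moves the number beyond the scatter. The expected step in this assay is accordingly a number no higher from compound 3 to compound 4 (the limit leaves the size open), held with little confidence in either direction. Compound 4 is estimated at 64000 nM, with a range from 25000 nM to 160000 nM, and a further limit rather than a number is as likely as not.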

Compound 4, half-maximal inhibitory concentration: 59300 nM
Estimate against measurement, compound 4: 1.1-fold (0.03 log units) above, and the stated range covers the measured number.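

Working note on the position, on a saturated chain carbon bound to a nitrogen on an aromatic ring in a ring: ((tert-butoxycarbonyl)amino)methyl is the only group shown here with no ring, and in this assay compound 4 gives a number, 59300 nM, rather than a limit. The steps read as an at least 1.0-fold lower number from compound 3 to compound 4 (0.03 log units; that floor lies within the scatter), an at least 1.0-fold lower number from compound 2 to compound 4 (0.03 log units; that floor lies within the scatter) and a 1.1-fold lower number from compound 1 to compound 4 (0.02 log units; within the scatter), so none of them moves beyond the scatter. Replacing the ring groups with this open group, which carries a hydrogen-bond donor and acceptors, therefore shows no readable gain, and the series stays at the edge of what the assay reports: the limit of > 64000 nM in this assay, at which 2 of the 4 values shown sit.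

The limits of compound 2 and compound 3 leave open how far those two compounds lie from compound 4. Also open, on these data alone, is whether an amine or a carboxylic acid in place of ((tert-butoxycarbonyl)amino)methyl, or a longer chain at this position, would bring the number in this assay clearly down from this level.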